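The source may hold more compounds than are shown below. What is called first, only, known or untested is meant among the compounds shown, and "the series" means these compounds.

Of the compounds shown here, two of the shared core have been measured. Compound 1 `FC(F)(F)c1ccc(CSc2nc(Nc3cccc(Cl)c3)c3ccccc3n2)cc1` gives 13400 nM in a functional assay on PC-3 cells (Homo sapiens) for cytotoxicity, read by MTT assay, with a stated time of 72 h (on this read-out lower numbers stand for stronger inhibition and higher numbers for weaker inhibition), and compound 2 `FC(F)(F)c1ccc(CSc2nc(Nc3ccc(Cl)cc3)c3ccccc3n2)cc1` gives 7110 nM. The single step between them, a 1.9-fold lower number from compound 1 to compound 2 (0.28 log units; within the scatter), moves chloro from one ring position to another and stays within the scatter, so on the numbers shown compound 2 holds the lower of the two values without standing apart from compound 1.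

Compound 3 `Cc1ccc(Nc2nc(SCc3ccc(C(F)(F)F)cc3)nc3ccccc23)cc1` differs from compound 2 by methyl in place of chloro on an aromatic carbon. No measured step exchanges chloro for methyl; the only step shown, from compound 1 to compound 2, moves the same group rather than replacing it and was itself within the scatter. Nothing in the data therefore points to a shift beyond the scatter, and the expected step of a 1.1-fold higher number from compound 2 to compound 3 (0.05 log units; within the scatter) is accordingly small. Compound 3 is estimated at 8000 nM, with a range from 3000 nM to 22000 nM.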

Compound 3, half-maximal inhibitory concentration: 21100 nM
Compound 3: middle estimate off by 2.6-fold (0.42 log units), on the low side; low and high end bracket the measured number.
By their numbers in this assay, from the lowest: compounds 2, 1 and 3 (each within the scatter of the next, the first and the last beyond it).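

In this assay, methyl in place of chloro on this aromatic carbon, para to a large group, gives a 3.0-fold higher number from compound 2 to compound 3 (0.47 log units; beyond the scatter) and is the only step among these compounds that lies beyond the scatter, so the identity of the group at this place can change the number, which moving chloro had not shown. The exchange of 3-chlorophenyl for 4-methylphenyl gives a 1.6-fold higher number from compound 1 to compound 3 (0.20 log units; within the scatter) and stays within the scatter, so the change from chloro to methyl reads clearly only against the 4-chlorophenyl of compound 2. Nothing available explains the difference between chloro and methyl here.

The compounds shown leave open whether fluoro or methoxy at this place would give numbers nearer to those of compound 2 or compound 3. They also leave open how an amine or a carboxylic acid there would read.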